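This account rests on a few compounds, and the source may have more. Where it says the series, first, only, none or still open, it means among the compounds named here.

Measured so far in a functional assay on NCI-H460 cells (Homo sapiens) for inhibition, read by sulforhodamine B assay, with a stated time of 72 h; on this read-out higher numbers stand for weaker inhibition and lower numbers for stronger inhibition:
- compound 1 `Cc1nc2cc(Br)ccc2n(CC(=O)NN)c1=O`: 0.00002 ug/mL
- compound 2 `Cc1nc2cc(Br)ccc2nc1Oc1ccc(N)cc1`: 0.00052 ug/mL
- compound 3 `Cc1nc2cc(Br)ccc2nc1Oc1ccc(/N=C\c2ccc(Cl)cc2)cc1`: 0.00008 ug/mL

Of these three numbers, compound 3 holds the middle place. Its value lies above that of compound 1 and below that of compound 2, and both gaps exceed the usual scatter of this assay.

The next compound is compound 4 `Cc1nc2cc(Br)ccc2nc1Oc1ccc(C=O)cc1`, which has not yet been measured. The change from compound 3 is a group of 2 heavy atoms (1 carbon, 1 oxygen; no ring) in place of a group of 9 heavy atoms (7 carbon, 1 nitrogen, 1 chlorine; one six-membered aromatic ring of carbon only), on an aromatic carbon. Formyl enters on an aromatic carbon of a six-membered aromatic ring of carbon only, para to a large group.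

Among the compounds with values here, one measured step bears on this change, and it runs the other way at the same aromatic carbon. It is a 6.5-fold lower number from compound 2 to compound 3 (0.81 log units; beyond the scatter), a modest step beyond the scatter, in which the larger group takes the place of one nitrogen atom. Compound 4, like compound 2, lacks that larger group, so part of this step is expected to be given back. Within the data shown here, no measured compound carries formyl, however, so the full return to the value of compound 2 cannot be assumed, and the uncertainty is wide. The expected change is a 3.1-fold higher number from compound 3 to compound 4 (0.49 log units; beyond the scatter), towards a higher number and weaker inhibition. For compound 4 the estimated value is 0.00025 ug/mL, with an expected range from 0.00005 ug/mL to 0.0012 ug/mL.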

Compound 4, half-maximal inhibitory concentration: 0.0285 ug/mL
For compound 4 the middle estimate is 110-fold (2.06 log units) below the measured one; measured number outside the range, above it.
By their numbers in this assay, from the lowest: compound 1; then compound 3; then compound 2; then compound 4.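

In this assay, within the data shown here, the group on this aromatic carbon proves far more decisive than the earlier compounds showed: formyl in place of the larger group of 9 heavy atoms brings a large loss of inhibition (a 360-fold higher number from compound 3 to compound 4 (2.55 log units; beyond the scatter)), well beyond the modest gain seen when that larger group replaced the nitrogen atom (a 6.5-fold lower number from compound 2 to compound 3 (0.81 log units; beyond the scatter)). Losing the larger group therefore does not simply return the number to that of compound 2, as formyl and amino on the same carbon also stand far apart (a 55-fold higher number from compound 2 to compound 4 (1.74 log units; beyond the scatter)). The read-out at this place thus depends on which group stands there and not only on whether the larger group is present, and among compound 2, compound 3 and compound 4, the formyl compound shows the weakest inhibition.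

Nothing available accounts for the wide gap between formyl and amino. As far as these compounds go, whether a carboxylic acid, a hydroxymethyl group or a longer amine chain on this carbon would fall nearer to formyl or to amino stays open, as does whether the low number of compound 3 rests on its chlorine, its carbon ring or its double bond outside aromatic rings.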